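A few compounds are considered here, and "the series" means these few. Any claim that something is new, unique, unknown or untested is made for them only; others in the source may bear on it.

Compound 2 `CC#C[C@@H](Cc1nnn[nH]1)c1ccc(OCc2ccc3scc(-c4cc(OCCOC)ccc4C)c3c2)cc1` gives 85 nM in a functional assay on cells for agonist activity at Free fatty acid receptor 1 (Homo sapiens), read by FLIPR and calcium flux (on this read-out higher numbers stand for an effect only at larger amounts of compound and lower numbers for an effect already at smaller amounts), the second highest of the three numbers recorded. Its nearest neighbour is compound 1 `CC#C[C@@H](Cc1nnn[nH]1)c1ccc(OCc2ccc3scc(-c4cccnc4C)c3c2)cc1`, which in this assay gives 88 nM, and its furthest is compound 3 `CC#C[C@@H](Cc1nnn[nH]1)c1ccc(OCc2cc(Cl)c3scc(-c4ccccc4C)c3c2)cc1`, which in this assay gives 63 nM; both gaps lie within the scatter. Compound 4 `CC#C[C@@H](Cc1nnn[nH]1)c1ccc(OCc2ccc3scc(C4CCCCC4)c3c2)cc1` differs from compound 2 by cyclohexyl in place of 5-(2-methoxyethoxy)-2-methylphenyl on an aromatic carbon. Within the data shown here, only one measured step touches this position: a 1.0-fold lower number from compound 1 to compound 2 (0.02 log units; within the scatter), which exchanged one aromatic ring for another. Among the measured compounds shown here, no measured step replaces the aromatic ring there with a non-aromatic one, so the evidence for the move to cyclohexyl is indirect. For the measured compounds named here, because the one comparable step, a 1.0-fold lower number from compound 1 to compound 2 (0.02 log units; within the scatter), stayed within the scatter, one expects for compound 4 at most a modest rise in the number, with considerable uncertainty. The estimated value for compound 4 is 200 nM, with a range from 70 nM to 700 nM. That estimate amounts to an expected step of a 2.4-fold higher number from compound 2 to compound 4 (0.37 log units; beyond the scatter).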

Compound 4, half-maximal effective concentration: 107 nM
Estimate against measurement, compound 4: 1.9-fold (0.27 log units) above; low and high end bracket the measured number.
By their numbers in this assay, from the lowest: compounds 3, 2, 1 and 4 (each within the scatter of the next).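

In this assay, the aromatic ring on this carbon of the five-membered ring can be replaced by a non-aromatic one with the number staying within the scatter: a 1.3-fold higher number from compound 2 to compound 4 (0.10 log units; within the scatter), and a 1.2-fold higher number from compound 1 to compound 4 (0.08 log units; within the scatter). Among these compounds, therefore, neither an aromatic ring at this place, nor the ring nitrogen of 2-methylpyridin-3-yl, nor the 2-methoxyethoxy chain of compound 2 is required for a number in this range, and cyclohexyl, with fewer heavy atoms than 5-(2-methoxyethoxy)-2-methylphenyl and no hydrogen-bond acceptors, serves as well. No measurement at hand explains this result.

On these data alone, it remains open whether a much smaller group such as methyl, or a group such as an amine or a carboxylic acid, would be accepted on this carbon. Also open, as far as these compounds go, is whether cyclohexyl would behave the same alongside the chlorine of compound 3.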